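This account rests on a few compounds, and the source may have more. Where it says the series, first, only, none or still open, it means among the compounds named here.

Compound 1, `COc1cccc(CSc2nnc([C@@H](C)c3ccc4cc(OC)ccc4c3)n2-c2ccc(F)cc2)c1`, gives 14500 nM in a functional assay on LNCaP cells (Homo sapiens) for cytotoxicity, read by MTT assay; on this read-out lower numbers stand for stronger inhibition and higher numbers for weaker inhibition.
Compound 2, `COc1ccc2cc([C@H](C)c3nnc(SCc4c(Cl)cccc4Cl)n3-c3cccc(Cl)c3)ccc2c1`, gives 73700 nM in this assay.
Compound 3, `COc1ccc2cc([C@H](C)c3nnc(SCc4ccc(Cl)cc4)n3-c3ccc(F)cc3)ccc2c1`, gives only the limit > 400000 nM in this assay, which is a limit of the assay and not a number.

Compound 3 therefore stands at the weak end of the three measured compounds, since its value is only a limit (the limit of > 400000 nM in this assay, at which 1 of the 3 values shown sits). Compound 4, `COc1ccc2cc([C@H](C)c3nnc(SCc4c(Cl)cccc4Cl)n3-c3ccc(F)cc3)ccc2c1`, has not yet been measured. It differs from compound 3 in one place: 2,6-dichlorophenyl in place of 4-chlorophenyl on a saturated chain carbon bound to a sulfur.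

Among the compounds with values here, only one measured step changes the group on the saturated chain carbon bound to the sulfur, and it is large: an at least 27-fold higher number from compound 1 to compound 3 (1.44 log units; beyond the scatter). It shows that this position moves the read-out strongly, though it does not involve the 2,6-dichlorophenyl group itself. Compound 2 carries the same 2,6-dichlorobenzyl group as compound 4 but a different ring on the shared core, so its value gives only a loose hint that this group is compatible with a measurable number.

Given that compound 3 is a limit, compound 4 is expected to give a lower number, with the estimated step of an at least 2.6-fold lower number from compound 3 to compound 4 (0.42 log units; beyond the scatter). For compound 4 the estimate in this assay is 150000 nM, with a range from 50000 nM to 400000 nM.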

Compound 4, half-maximal inhibitory concentration: 12300 nM
Compound 4: middle estimate off by 12-fold (1.09 log units), on the high side; the measured number lies below the stated range.
By their numbers in this assay, from the lowest: compounds 4 and 1 (each within the scatter of the next); then compound 2. At a limit, above all of these: compound 3.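

In this assay, 2,6-dichlorophenyl in place of 4-chlorophenyl on a saturated chain carbon bound to a sulfur gives an at least 32-fold lower number from compound 3 to compound 4 (1.51 log units; beyond the scatter), so the large step seen earlier at this position is not a general penalty for a chlorinated ring here. The size of that step is only a bound, as the value of compound 3 is a limit of the assay and not a number: the limit of > 400000 nM in this assay, at which 1 of the 4 values shown sits. The 2,6-dichlorophenyl and 3-methoxyphenyl groups cannot be told apart at this position, with a 1.2-fold lower number from compound 1 to compound 4 (0.07 log units; within the scatter), while with 2,6-dichlorophenyl held fixed, 4-fluorophenyl in place of 3-chlorophenyl on an aromatic nitrogen gives a 6.0-fold lower number from compound 2 to compound 4 (0.78 log units; beyond the scatter), so the read-out also responds to that second position.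

The compounds shown do not tell whether the number of chlorine atoms or their placing separates compound 3 from compound 4, and a plain phenyl group or a cyclohexyl group at this position would bear on that. They also leave open whether the 4-chlorophenyl group behaves the same way with a 3-chlorophenyl group on the aromatic nitrogen.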